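Benzyl to (methoxycarbonyl)methyl on the shared core

The compounds below may be only part of what the source reports. "The series", "measured", "known", "first", "only" and "open" are said of these compounds alone.

compound 1 `CCc1c(C(=O)OC)[nH]c2cc(OC)ccc12`: > 100000 nM
compound 2 `COC(=O)c1[nH]c2cc(OC)ccc2c1C1CCCCC1`: 80200 nM
compound 3 `COC(=O)c1[nH]c2cc(OC)ccc2c1Cc1ccccc1`: 8700 nM

All three compounds were tested in a functional assay on CCRF-CEM cells (Homo sapiens) for antiproliferative activity, read by MTT assay, with a stated time of 48 h; a lower number here means that less compound is needed, a higher number that more compound is needed for the effect. Compound 1 shows > 100000 nM, which is a limit and not a number.

Compound 3 stands lowest in this assay, at 8700 nM. Compound 4 `COC(=O)Cc1c(C(=O)OC)[nH]c2cc(OC)ccc12` differs from it in one place: methoxycarbonyl in place of phenyl on a saturated chain carbon bound to an aromatic carbon. This puts methoxycarbonyl in place of phenyl on a saturated chain carbon bound to an aromatic carbon.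

Among the compounds with values here, two measured steps bear on this change. The nearest is an at least 11-fold lower number from compound 1 to compound 3 (1.06 log units; beyond the scatter), where phenyl replaces methyl at that same kind of carbon. The other is a 9.2-fold lower number from compound 2 to compound 3 (0.96 log units; beyond the scatter), where benzyl replaces cyclohexyl. Both compounds without the phenyl, compound 1 and compound 2, therefore sit higher than compound 3. Within the data shown here, no measured compound carries methoxycarbonyl, so this comparison is only indirect.

A large rise is expected, with an estimated 6.9-fold higher number from compound 3 to compound 4 (0.84 log units; beyond the scatter). Compound 4 is expected at about 60000 nM, within an estimated range of 15000 nM to 200000 nM.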

Compound 4, half-maximal effective concentration: > 100000 nM
Compound 4: no number, only a limit (the forecaster's own chance of this, stated with the estimate: 45%); middle value at least 1.6-fold (0.22 log units) from the limit.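

In this assay compound 4 gives > 100000 nM, which is a limit and not a number. Methoxycarbonyl in place of phenyl on a saturated chain carbon bound to an aromatic carbon gives an at least 11-fold higher number from compound 3 to compound 4 (1.06 log units; beyond the scatter), so the lower number of compound 3 is lost with this ester group, as it is with the methyl of compound 1. (Methoxycarbonyl)methyl in place of cyclohexyl gives an at least 1.2-fold higher number from compound 2 to compound 4 (0.09 log units; that floor lies within the scatter), a floor within the scatter, and the step from compound 1 to compound 4 cannot be read, because both values are limits: the limit of > 100000 nM in this assay, at which 2 of the 4 values shown sit.

As far as these compounds go, how far compound 4 lies past its limit stays open. Also open, from the compounds shown here alone, is whether the phenyl ring itself carries the effect, which a pyridine ring or a longer chain ending in phenyl, such as 2-phenylethyl, at this place could test.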